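The source may hold more compounds than are shown below. What is called first, only, known or untested is meant among the compounds shown, and "the series" means these compounds.

Compound 2 `Cc1cc(NCc2ccccn2)n2ncc(-c3c(C)cccc3C)c2n1` was tested in a physicochemical assay for solubility, read by HPLC, using the shake flask method, measured as kinetic solubility, with a stated time of 2 h, at pH 7.4; on this read-out higher numbers stand for higher solubility and lower numbers for lower solubility. In this assay compound 2 gives only a limit of the assay, < 5000 nM, not a number. Compound 1 `Cc1cc(NCc2ccccn2)n2ncc(-c3ccc(F)cc3)c2n1` likewise gives only a limit, < 5000 nM. Because of the limit of < 5000 nM in this assay, at which 2 of the 3 values shown sit, the step between them is a step that the two limits leave unreadable from compound 1 to compound 2. Among the measured compounds shown here, compound 3 `CCN1CCCC1CNc1cc(C)nc2c(-c3ccccc3)c(C)nn12`, which differs in several places, gives 172000 nM and is the only value that is a number. Compound 4 `Cc1cc(NCc2ccccn2)n2ncc(-c3ccc(O)cc3)c2n1` has not yet been measured; it differs from compound 2 by 4-hydroxyphenyl in place of 2,6-dimethylphenyl on an aromatic carbon. For the measured compounds named here, no measured step bears directly on this change, and the one recorded step is unreadable, so the expectation rests on the limit alone. Compound 4 is expected to give 8000 nM, with a range from 2000 nM to 40000 nM. The expected step is an at least 1.6-fold higher number from compound 2 to compound 4 (0.20 log units; that floor lies within the scatter), upward but uncertain.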

Compound 4, solubility: 10900 nM
Beside the measured number, compound 4's estimate is 1.4-fold (0.13 log units) below it; the range from low to high includes it.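

Among the compounds shown here, on the aromatic carbon of the five-membered ring, the earlier compounds gave only limits in this assay, but 4-hydroxyphenyl now gives a number, with an at least 2.1-fold higher number from compound 2 to compound 4 (0.33 log units; beyond the scatter). The smaller change, hydroxy in place of fluoro, also reaches beyond the scatter, with an at least 2.1-fold higher number from compound 1 to compound 4 (0.33 log units; beyond the scatter). Both sizes are floors rather than exact steps because the starting compounds sit at a limit: the limit of < 5000 nM in this assay, at which 2 of the 4 values shown sit.

Still open, going by these compounds, is how an amine or a carboxylic acid in place of the hydroxy would read in this assay. Also open, on these data alone, is how far the true steps exceed these floors.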